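This account rests on a few compounds, and the source may have more. Where it says the series, first, only, none or still open, it means among the compounds named here.

In a functional assay on MDA-MB-231 cells (Homo sapiens) for cytotoxicity, read by MTT assay, with a stated time of 72 h (on this read-out higher numbers stand for weaker inhibition and lower numbers for stronger inhibition), three compounds that share one core have been measured, and they differ only in the ring on a saturated chain carbon bound to an amide-type nitrogen. Compound 1 `Nc1ccccc1NC(=O)c1ccc(NC(=S)NCc2ccc(Cl)nc2)cc1` gives 42000 nM. Compound 2 `Nc1ccccc1NC(=O)c1ccc(NC(=S)NCc2ccccc2F)cc1` gives > 100000 nM, which is a limit of the assay and not a number. Compound 3 `Nc1ccccc1NC(=O)c1ccc(NC(=S)NCc2cncc(F)c2)cc1` gives 85000 nM, the higher of the two true numbers, and the nearest of these is that of compound 1: a 2.0-fold higher number from compound 1 to compound 3 (0.31 log units; beyond the scatter).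

Compound 4 `Cc1ccc(CNC(=S)Nc2ccc(C(=O)Nc3ccccc3N)cc2)cn1` has 6-methylpyridin-3-yl in place of 5-fluoropyridin-3-yl on a saturated chain carbon bound to an amide-type nitrogen. Among the measured compounds shown here, the best guide is the one measured swap of one substituted pyridine ring for another, which was modest: a 2.0-fold higher number from compound 1 to compound 3 (0.31 log units; beyond the scatter). The swap of a fluorinated benzene ring for a pyridine ring gives little more to go on: an at least 1.1-fold lower number from compound 2 to compound 3 (0.07 log units; that floor lies within the scatter). Neither step suggests a large change, so only a small drop, within the scatter, is expected: a 1.4-fold lower number from compound 3 to compound 4 (0.15 log units; within the scatter). For compound 4 the estimate is 60000 nM, with an expected range from 28000 nM to 100000 nM.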

Compound 4, half-maximal inhibitory concentration: 63000 nM
Compound 4: the middle estimate sits 1.1-fold (0.02 log units) below what was measured; measured number inside the range.
By their numbers in this assay, from the lowest: compounds 1, 4 and 3 (each within the scatter of the next, the first and the last beyond it). At a limit, above all of these: compound 2.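

In this assay, the chloro and methyl groups can now be compared on otherwise matching rings, 6-chloropyridin-3-yl and 6-methylpyridin-3-yl, and the step stays within the scatter: a 1.5-fold higher number from compound 1 to compound 4 (0.18 log units; within the scatter). The change from 5-fluoropyridin-3-yl to 6-methylpyridin-3-yl also stays within the scatter: a 1.3-fold lower number from compound 3 to compound 4 (0.13 log units; within the scatter). Against the 2-fluorophenyl ring, whose result is a limit and not a number, only a floor can be read, and that floor lies within the scatter: an at least 1.5-fold lower number from compound 2 to compound 4 (0.20 log units; that floor lies within the scatter).

Still open, going by these compounds, is whether an amine or a carboxylic acid on the pyridine ring would shift the number beyond the scatter. The same question applies to a longer chain between the ring and the amide-type nitrogen.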